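Sulfonylpiperidine ester series: carboxamide in place of sulfonamide

The compounds below may be only part of what the source reports. "The series", "measured", "known", "first", "only" and "open" are said of these compounds alone.

Compound 1 `CCOC(=O)[C@@H]1CCCN(S(=O)(=O)c2ccc(S(=O)(=O)N3CCCCC3)cc2)C1` is the ethyl ester of the series, carrying a (piperidin-1-yl)sulfonyl group on the aryl ring. In a functional assay on MIA PaCa-2 cells (Homo sapiens) for inhibition, read by MTT assay, with a stated time of 3 days (a lower number here means a stronger inhibitor, a higher number a weaker inhibitor), compound 1 gives 1000 nM. Compound 2 `CCN(CC)S(=O)(=O)c1ccc(S(=O)(=O)N2CCC[C@@H](C(=O)N3CCN(c4nnc(C(C)C)o4)CC3)C2)cc1` replaces the ester with a larger amide and carries a diethylsulfamoyl group instead; in this assay compound 2 gives 1000 nM. The two values are level at the digits shown, so compound 1 and compound 2 lie within the scatter of each other and no order between them can be stated.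

Compound 3 `CCOC(=O)[C@@H]1CCCN(S(=O)(=O)c2ccc(C(=O)N(CC)CC)cc2)C1` is the next member and has not yet been measured. Against compound 1 the change is diethylcarbamoyl in place of (piperidin-1-yl)sulfonyl on an aromatic carbon, para to a large group. Within the data shown here, no measured pair isolates this change. Among the measured compounds shown here, the only comparison in hand, between compound 1 and compound 2, shows that varying the groups on both ends of the core left the reading unchanged. On that basis no step beyond the scatter is expected; the estimated step is no change at the digits printed from compound 1 to compound 3 (within the scatter). Compound 3 is expected at 1000 nM, with a range from 400 nM to 2500 nM.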

Compound 3, half-maximal inhibitory concentration: 100 nM
Compound 3: the middle estimate sits 10-fold (1.00 log units) above what was measured; the whole stated range lies above it.
By their numbers in this assay, from the lowest: compound 3; then compounds 1 and 2 (each within the scatter of the next).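

In this assay, among these compounds, the swap of (piperidin-1-yl)sulfonyl for diethylcarbamoyl on an aromatic carbon, para to a large group, gives a 10-fold lower number from compound 1 to compound 3 (1.00 log units; beyond the scatter), the first single-place change that can be read. The reading therefore responds to the group at this position while the ethyl ester and the rest of the core stay fixed, something compound 1 and compound 2 could not show, since they differ in more than one place. Nothing at hand accounts for the size of this step.

The change replaces the sulfonyl with a carbonyl and the six-membered non-aromatic ring with an open diethyl pair at once, so the compounds shown do not separate these two parts; a piperidin-1-ylcarbonyl group at the same position would be the direct test. Also open, going by these compounds, is whether the step holds when the ethyl ester gives way to the larger amide of compound 2 or to a carboxylic acid, as this change has been read only on the ester.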